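Methoxy added to the aryl ketone of a pyrazole chalcone

The compounds below may be only part of what the source reports. "The series", "measured", "known", "first", "only" and "open" are said of these compounds alone.

Compound 1 `COc1cc(-c2cc(/C=C/C(=O)c3ccc(Cl)c(Cl)c3)[nH]n2)cc(OC)c1OC` in a functional assay on UO-31 cells (Homo sapiens) for inhibition, read by sulforhodamine B assay, with a stated time of 48 h; a higher number here means a weaker inhibitor of growth, a lower number a stronger inhibitor of growth: > 100000 nM
Compound 2 `COc1ccc(C(=O)/C=C/c2cc(-c3cc(OC)c(OC)c(OC)c3)n[nH]2)cc1OC` in this assay: 2570 nM

The value for compound 1 is a limit of this assay, not a number. Within the data shown here, compound 2 gives the only number in this assay. Among the measured compounds shown here, the one measured step, an at least 38-fold lower number from compound 1 to compound 2 (1.59 log units; beyond the scatter), changes the aryl group on the carbonyl carbon and is large; the change from compound 2 to compound 3 `COc1cc(C(=O)/C=C/c2cc(-c3cc(OC)c(OC)c(OC)c3)n[nH]2)cc(OC)c1OC` is smaller, (methoxy in place of hydrogen on an aromatic carbon), on that same aryl group. For the measured compounds named here, no measured step matches this change, so for compound 3 the expected step of a 1.3-fold lower number from compound 2 to compound 3 (0.11 log units; within the scatter) is within the scatter, with no direction claimed. Compound 3 is estimated at 2000 nM, ranging from 500 nM to 8000 nM.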

Compound 3, concentration for total growth inhibition: 2480 nM
Beside the measured number, compound 3's estimate is 1.2-fold (0.09 log units) below it; low and high end bracket the measured number.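

In this assay, methoxy in place of hydrogen on the aryl ketone gives a 1.0-fold lower number from compound 2 to compound 3 (0.02 log units; within the scatter) and so separates neither compound from the other. The earlier step showed that exchanging the substituents of the whole aryl group can matter a great deal; this one shows that the aryl ketone tolerates a third methoxy at this position without a readable difference. No measurement shown accounts for this.

Going by these compounds, whether this position also tolerates an amine, a carboxylic acid or a longer chain such as ethoxy remains open.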